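Swapping the N-aryl group on the pyridazinone amide

The source may hold more compounds than are shown below. What is called first, only, known or untested is meant among the compounds shown, and "the series" means these compounds.

Measured compounds:
Compound 1 `COc1cc2c(Oc3ccc(NC(=O)c4nn(-c5ccccc5C)c(=O)cc4C)cc3F)ccnc2cc1OCCCN1CCCCC1`: 1920 nM
Compound 2 `COc1cc2c(Oc3ccc(NC(=O)c4nn(-c5ccccc5C)c(=O)cc4C)cc3F)ccnc2cc1OCCCN1CCC(C)CC1`: 1460 nM

Compound 1 and compound 2 share one core and differ only at the saturated ring at the chain end, where compound 2 carries a methyl in place of hydrogen on a saturated ring carbon. In a functional assay on A549 cells (Homo sapiens) for inhibition, read by MTT assay, with a stated time of 72 h (a lower number here means a stronger inhibitor, a higher number a weaker inhibitor), compound 1 gives 1920 nM and compound 2 gives 1460 nM; the step of a 1.3-fold lower number from compound 1 to compound 2 (0.12 log units; within the scatter) lies within the scatter, so the two compounds stand level and neither can be called the stronger inhibitor.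

Compound 3 `COc1cc2c(Oc3ccc(NC(=O)c4nn(-c5cccc(F)c5)c(=O)cc4C)cc3F)ccnc2cc1OCCCN1CCC(C)CC1` keeps the methyl-bearing saturated ring of compound 2 and alters a different place: 3-fluorophenyl in place of 2-methylphenyl on an aromatic nitrogen. Among the measured compounds shown here, no measured step touches this aryl group, so nothing in the two values tells which way the number will move. For the measured compounds named here, the single step from compound 1 to compound 2 concerns another part of the molecule and does not bear on this change. The estimate for compound 3 therefore stays close to compound 2, with a wide range in both directions: 1500 nM (from 500 nM to 4500 nM), which is expected to mean a step of a 1.0-fold higher number from compound 2 to compound 3 (0.01 log units; within the scatter).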

Compound 3, half-maximal inhibitory concentration: 250 nM
Compound 3: middle estimate off by 6.0-fold (0.78 log units), on the high side; measured number below the stated range.
By their numbers in this assay, from the lowest: compound 3; then compounds 2 and 1 (each within the scatter of the next).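

In this assay, the aryl group on the aromatic nitrogen proves to be a place where the number responds, with a 5.8-fold lower number from compound 2 to compound 3 (0.77 log units; beyond the scatter) for 3-fluorophenyl in place of 2-methylphenyl. Among the compounds shown here, this is the first step to lie beyond the scatter, whereas the methyl on the saturated ring left compound 1 and compound 2 level. Nothing available explains why this exchange lowers the number.

The exchange removes a methyl and adds a fluorine at once, so the compounds shown do not separate the share of each, which a plain phenyl group, 2-fluorophenyl or 3-methylphenyl on the same nitrogen would address. From the compounds shown here alone, it also remains open whether 3-chlorophenyl or 3-methoxyphenyl would behave like 3-fluorophenyl, and whether the step carries over to the saturated ring without its methyl.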